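The source may report more compounds than this note shows. Statements on the series, on what has been measured and on what is new or still open speak of the compounds shown alone.

Measured so far in a functional assay on the whole organism for inhibition, with Rattus norvegicus as the target, at a dose of 30 mg/kg; on this read-out lower numbers stand for less inhibition and higher numbers for more inhibition at the one dose given (going by the name of the read-out):

Compound 1, `Fc1ccc(-c2nc3cccnc3o2)cc1`, gives 27%.
Compound 2, `Clc1ccc(-c2nc3ncccc3o2)cc1`, gives 24%.

Among the compounds with values here, both compounds share a core made of two fused rings carrying a substituted benzene ring, and they differ from each other in more than one place, so no single step connects them. Their two numbers lie within the scatter of each other, so compound 1 cannot be set apart from compound 2 on these data. Compound 3, `Clc1ccc(-c2nc3cccnc3o2)cc1`, is the unmeasured compound; it differs from compound 1 in one place: chloro in place of fluoro on an aromatic carbon. Within the data shown here, no pair with this exact change has been measured, but compound 2, which also carries chloro, gives 24%, a number within the scatter of compound 1. The expectation is therefore a step from compound 1 to compound 3 of about a number 1 percentage points lower from compound 1 to compound 3 (within the scatter), no larger than the scatter. Compound 3 is estimated at 26%, between 10% and 42%.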

Compound 3, a percentage reported as inhibition, in the whole organism at one dose (the size of the read-out at that dose, not a potency): 14%
For compound 3 the middle estimate is 12 percentage points above the measured one; measured number inside the range.
By their numbers in this assay, from the lowest: compounds 3, 2 and 1 (each within the scatter of the next, the first and the last beyond it).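

In this assay, within the data shown here, chloro in place of fluoro at this position gives a step of a number 13 percentage points lower from compound 1 to compound 3 (beyond the scatter), and this is the first comparison here in which only one place changes. Compound 1 and compound 2 differ in more than one place, so their numbers could not show what this swap does on its own; the new pair shows that exchanging one halogen for the other on this aromatic carbon can move the read-out beyond the usual scatter, though only modestly. Nothing available explains the size or direction of this step.

Going by these compounds, how a methoxy group or an amine at this same position would compare remains open. Also open, on these data alone, is whether the same swap would give a similar step on the core of compound 2.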